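Swapping the acyl ring in a cytotoxic anilide series

The compounds below may be only part of what the source reports. "The series", "measured", "known", "first", "only" and "open" are said of these compounds alone.

Measured compounds:
compound 1, `O=C(Nc1cc(C(F)(F)F)ccc1Nc1ccc(Br)cc1)c1cccnc1Cl`, 20600 nM
compound 2, `O=C(Nc1cc(C(F)(F)F)ccc1N1CCCCC1)c1ccccc1`, "not active" (no number reported)

Of the compounds shown here, two have been tested in a functional assay on Jurkat cells (Homo sapiens) for cytotoxicity, read by MTT assay, with a stated time of 48 h; on this read-out higher numbers stand for weaker inhibition and lower numbers for stronger inhibition. Compound 1 gives 20600 nM, a weak result. Compound 2 is reported as "not active" (no number reported) in this assay, so no single number is available for it and its standing can only be described as below the range at which a value was obtained. Compound 3, `O=C(Nc1cc(C(F)(F)F)ccc1N1CCCCC1)c1cccnc1Cl`, remains to be measured. Relative to compound 2 the change is 2-chloropyridin-3-yl in place of phenyl on a carbonyl carbon. Compound 1 carries that same acyl group and gives only a weak value in this assay, while compound 2, with the same piperidinyl-bearing core as compound 3, gives none. Within the data shown here, with no measured step between these structures, the direction of the change cannot be read from the data; any gain beyond the scatter would have to come from the new acyl ring alone, and compound 1 offers no sign of a strong effect from it. Compound 3 is therefore expected to be weak, estimated at 40000 nM with a range from 10000 nM to 150000 nM, with a real chance that this assay again reports no number.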

Compound 3, half-maximal inhibitory concentration: "not active" (no number reported)
The entry for compound 3 holds no number, so the estimate cannot be set against anything.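

Compound 2 and compound 3 both lack a number in this assay and so no step can be read between them. No available evidence bears on this result. The compounds shown leave open whether 2-chloropyridin-3-yl in place of phenyl on the carbonyl carbon changes the read-out at all in this assay.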